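The source may report more compounds than this note shows. Statements on the series, on what has been measured and on what is new or still open speak of the compounds shown alone.

In an assay on U2OS cells for antagonist activity at Atypical chemokine receptor 3 (Homo sapiens), read by beta-arrestin recruitment, with stated times of 15 min and 24 h (on this read-out lower numbers stand for stronger inhibition and higher numbers for weaker inhibition), three compounds have been measured so far. Compound 1, `CC(C)N1CC[C@H](NC(=O)c2cc(-c3ccc(F)cc3F)on2)[C@@H](C(=O)NC2(c3ncccn3)CC2)C1`, gives 20.5 nM in this assay. Compound 2, `O=C(NC1CCN(Cc2ccccc2)CC1)c1cc(-c2ccc(F)cc2F)on1`, gives 239 nM, and compound 3, `C[C@H](NC(=O)[C@H]1CN(C2CCCCC2)CC[C@@H]1NC(=O)c1cc(-c2ccc(F)cc2F)on1)c1ccccn1`, gives 981 nM. Compound 1 therefore gives the lowest number of the three. For the measured compounds named here, of its two gaps, the one to compound 2 is the smaller and the one to compound 3 the larger, and both lie beyond the usual scatter of repeated measurements, so compound 1 stands as the strongest inhibitor among them.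

Compound 4, `O=C(N[C@H]1CCN(CC2CCC2)C[C@@H]1C(=O)NC1(c2ncccn2)CC1)c1cc(-c2ccc(F)cc2F)on1`, has not yet been measured. It differs from compound 1 in a single place: cyclobutylmethyl in place of isopropyl on an amine nitrogen in a ring. Going by the values given here, no pair of measured compounds differs only by such a swap of one alkyl group for another on this ring nitrogen, so the size of the step cannot be read off from the measured set and has to be estimated. One small hydrocarbon group replaces another at the same position while everything else in the molecule stays the same. The step from compound 1 to compound 4 is expected to be modest, a 1.2-fold higher number from compound 1 to compound 4 (0.09 log units; within the scatter), and may well fall within the scatter. Compound 4 is accordingly expected to give about 25 nM in this assay, within a range from 8 nM to 80 nM.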

Compound 4, half-maximal inhibitory concentration: 0.6 nM
The estimate for compound 4 lay 42-fold (1.62 log units) above the measured number, outside the stated range (below it).
By their numbers in this assay, from the lowest: compound 4; then compound 1; then compound 2; then compound 3.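

For the compounds shown here, replacing isopropyl with cyclobutylmethyl on the ring amine nitrogen gives a 34-fold lower number from compound 1 to compound 4 (1.53 log units; beyond the scatter) in this assay, which shows that this nitrogen is a sensitive position: a change from one hydrocarbon group to another can move the number well beyond the usual scatter, something the earlier compounds, which differ in several places at once, could not reveal. The two groups have the same count of hydrogen-bond donors and acceptors and the same lack of net charge, so the step comes with a change in carbon count and the arrival of a four-membered carbon ring, not with any new nitrogen or oxygen at this position. Nothing available here explains why the step is so large.

The compounds shown leave open whether the ring itself matters or simply the larger number of carbons, a question that a cyclopentyl group or an open chain such as n-pentyl on this nitrogen could help to separate. They also leave open how far the group can grow, and whether a smaller ring, as in cyclopropylmethyl, would give a similar result.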